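Methoxy to 4-methylpiperazin-1-yl on two related cores

A few compounds are considered here, and "the series" means these few. Any claim that something is new, unique, unknown or untested is made for them only; others in the source may bear on it.

Measured compounds in an assay on isolated protein for inhibition of protein kinase C zeta type (Homo sapiens), read by mobility shift assay, tested at 30 uM; on this read-out higher numbers stand for more inhibition at the one concentration tested (going by the name of the read-out) and lower numbers for less inhibition:

compound 1 `COc1ccc(-c2cc3[nH]nc(N)c3c(=O)[nH]2)cc1`: 7%
compound 2 `CN1CCN(c2ccc(-c3cc4[nH]nc(N)c4c(=O)[nH]3)cc2)CC1`: 35%
compound 3 `COc1ccc(-c2cc3nn(-c4ccccc4)c(N)c3c(=O)[nH]2)cc1`: 0%

Compounds 1 and 2 share a core and differ in one place: 4-methylpiperazin-1-yl in place of methoxy on an aromatic carbon. This change gives a number 28 percentage points higher from compound 1 to compound 2 (beyond the scatter) in this assay. Compound 3 carries a different core; the difference between the two cores is not broken down here. Compound 3 stands lowest of the three numbers, but its gap to compound 1 is within the scatter, so no order between compound 3 and compound 1 is claimed; its gap to compound 2 is beyond the scatter.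

Compound 4 `CN1CCN(c2ccc(-c3cc4nn(-c5ccccc5)c(N)c4c(=O)[nH]3)cc2)CC1` is not yet measured. It relates to compound 3 as compound 2 relates to compound 1: 4-methylpiperazin-1-yl in place of methoxy on an aromatic carbon. The place lines of the two changes read the same, so this is the same change, now carried out on the core of compound 3. The change has been seen only once among the measured compounds, so how it transfers to the second core is open. The expectation is a step of a number 20 percentage points higher from compound 3 to compound 4 (beyond the scatter) from compound 3 to compound 4, somewhat smaller than the measured one, because the measured step of a number 28 percentage points higher from compound 1 to compound 2 (beyond the scatter) stands on a core for which the starting compound already shows some inhibition, while compound 3 gives 0%. On that basis compound 4 is estimated at 20% in this assay, with the range 0% to 45%.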

Compound 4, a percentage reported as inhibition, at one concentration (the size of the read-out at that concentration, not a potency): 23%
Beside the measured number, compound 4's estimate is 3 percentage points below it; low and high end bracket the measured number.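

In this assay, 4-methylpiperazin-1-yl in place of methoxy on the aromatic carbon gives a number 23 percentage points higher from compound 3 to compound 4 (beyond the scatter), so the second core shows a step in the same direction as the first. Set side by side, the two steps do not separate in size: the same change on two cores in this assay, a number 28 percentage points higher (beyond the scatter) from compound 1 to compound 2 and a number 23 percentage points higher (beyond the scatter) from compound 3 to compound 4, 5 percentage points apart, within the scatter of two such steps. This supports treating the change as portable between these two cores only; it rests on one pair per core, and a percentage at a single concentration is not a potency, so it says nothing about other cores, about other groups at this place, or about why the step arises.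

As far as these compounds go, it remains open which part of 4-methylpiperazin-1-yl carries the step, since morpholin-4-yl, piperazin-1-yl without the methyl or an open-chain dimethylamino group would each separate the ring, the second ring nitrogen and the methyl from one another. Also open, from the compounds shown here alone, is whether the step holds when the phenyl group on the core of compound 3 is exchanged for a smaller group such as methyl, which would test the transfer on a third core.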